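This account rests on a few compounds, and the source may have more. Where it says the series, first, only, none or still open, it means among the compounds named here.

Values from an assay on CHO cells for displacement of a labelled ligand from adenosine receptor A1 (Homo sapiens), read by scintillation counting, with a stated time of 3 h; on this read-out higher numbers stand for weaker inhibition and lower numbers for stronger inhibition:

compound 1 `N#Cc1cccc(-c2nc(N)c3nc(-c4ccccc4)sc3n2)c1`: 594 nM
compound 2 `Nc1nc(-c2cccc(O)c2)nc2sc(-c3ccccc3)nc12`: 58.5 nM
compound 3 `N#Cc1cccc(-c2nc(N)c3nc(-c4ccco4)sc3n2)c1`: 103 nM

Compound 4 `Nc1nc(-c2cccc(O)c2)nc2sc(-c3ccco3)nc12` is not yet measured in this assay.

The two cores differ in this way: furan-2-yl in place of phenyl on an aromatic carbon; that step is a 5.8-fold lower number from compound 1 to compound 3 (0.76 log units; beyond the scatter).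

Compound 3 and compound 4 differ in this way: hydroxy in place of cyano on an aromatic carbon. The same change has already been made once, from compound 1 to compound 2, as hydroxy in place of cyano on an aromatic carbon, and there the step was a 10-fold lower number from compound 1 to compound 2 (1.01 log units; beyond the scatter). The place lines of the two changes read alike, so it is the same change on a different core.

Within the data shown here, for compound 4 the step in this assay is expected to be of similar size, estimated as a 7.4-fold lower number from compound 3 to compound 4 (0.87 log units; beyond the scatter), resting on the single earlier step of a 10-fold lower number from compound 1 to compound 2 (1.01 log units; beyond the scatter) and on compound 3 already standing at 103 nM. Whether the change carries over on the second core is only an expectation from one precedent. Compound 4 is therefore estimated at 14 nM, with a range of 4 nM to 45 nM.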

Compound 4, inhibition constant: 51 nM
The estimate for compound 4 lay 3.6-fold (0.56 log units) below the measured number; measured number outside the range, above it.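

In this assay, hydroxy in place of cyano still gives a lower number on the core carrying furan-2-yl, a 2.0-fold lower number from compound 3 to compound 4 (0.31 log units; beyond the scatter), but the step does not keep its size: the same change on two cores in this assay, a 10-fold lower number (1.01 log units; beyond the scatter) from compound 1 to compound 2 and a 2.0-fold lower number (0.31 log units; beyond the scatter) from compound 3 to compound 4, 5.0-fold (0.70 log units) apart, beyond the scatter of two such steps. Furan-2-yl in place of phenyl on the hydroxy compounds gives a step within the scatter, a 1.1-fold lower number from compound 2 to compound 4 (0.06 log units; within the scatter), so that change does not carry over in size either: the same change on two cores in this assay, a 5.8-fold lower number (0.76 log units; beyond the scatter) from compound 1 to compound 3 and a 1.1-fold lower number (0.06 log units; within the scatter) from compound 2 to compound 4, 5.0-fold (0.70 log units) apart, beyond the scatter of two such steps. In these four compounds, the size of a step on one core is a poor guide to its size on the other, but they do not show why, or whether the direction would hold on further cores.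

Still open, from the compounds shown here alone, is whether an amine or a methoxy group on the same aromatic carbon would behave as hydroxy does. Going by these compounds, it is also open whether the two cores would again differ with such groups.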